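The source may hold more compounds than are shown below. What is called first, only, known or untested is meant among the compounds shown, and "the series" means these compounds.

Working notes on the series. Compound 1 `COc1ccc(CN(C(=O)CSC(=S)N2CCOCC2)c2cc(OC)c(OC)c(OC)c2)cc1` carries a morpholin-4-yl group on the thiocarbonyl carbon of the shared core. In a functional assay on HCT-116 cells (Homo sapiens) for inhibition, read by CCK-8 assay, with a stated time of 48 h (on this read-out lower numbers stand for stronger inhibition and higher numbers for weaker inhibition), compound 1 gives 4130 nM. Going by the values given here, only one other member has been measured, compound 2 `COc1ccc(CN(C(=O)CSC(=S)N2CCCc3cc(C)ccc32)c2cc(OC)c(OC)c(OC)c2)cc1`, in which 6-methyl-1,2,3,4-tetrahydroquinolin-1-yl stands in place of morpholin-4-yl on a thiocarbonyl carbon; in this assay compound 2 gives 5230 nM, so that the step of a 1.3-fold higher number from compound 1 to compound 2 (0.10 log units; within the scatter) leaves the two numbers indistinguishable. Compound 1 therefore has no measured partner that differs from it beyond the scatter.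

The next member is compound 3 `COc1ccc(CN(C(=O)CSC(=S)N2CCCc3cc(OC)ccc32)c2cc(OC)c(OC)c(OC)c2)cc1`. Its difference from compound 1 is 6-methoxy-1,2,3,4-tetrahydroquinolin-1-yl in place of morpholin-4-yl on a thiocarbonyl carbon. Among the compounds with values here, the only measured step that bears on this change is a 1.3-fold higher number from compound 1 to compound 2 (0.10 log units; within the scatter), which exchanged morpholin-4-yl for the same tetrahydroquinolinyl group carrying methyl rather than methoxy; that exchange stayed within the scatter. Nothing else is known about a methoxy on this group. The expectation for compound 3 is therefore a number close to compound 1 with no step beyond the scatter, the expected step being a 1.2-fold higher number from compound 1 to compound 3 (0.08 log units; within the scatter). Compound 3 is estimated at 5000 nM in this assay, in the range 2500 nM to 10000 nM.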

Compound 3, half-maximal inhibitory concentration: > 20000 nM
Compound 3 ended at the assay's limit; the forecaster's own chance of this, stated with the estimate: 5%; at least 4.0-fold (0.60 log units) between middle value and limit.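

In this assay compound 3 stands at a limit of the assay and not at a number: the limit of > 20000 nM in this assay, at which 1 of the 3 values shown sits. On the thiocarbonyl carbon, the exchange of morpholin-4-yl for a substituted tetrahydroquinolin-1-yl group is no longer uniformly silent, since it gives an at least 4.8-fold higher number from compound 1 to compound 3 (0.68 log units; beyond the scatter), whereas the same exchange with the methyl-bearing group stayed within the scatter. The series' clearest single-place signal is therefore on the aromatic carbon of that group, where methoxy in place of methyl gives an at least 3.8-fold higher number from compound 2 to compound 3 (0.58 log units; beyond the scatter), showing that the read-out at this position depends on that one substituent and not only on the presence of the tetrahydroquinolin-1-yl group.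

The compounds shown leave open whether the difference belongs to methoxy specifically, as a fluorine, a chlorine, a hydroxyl or an amine on the same aromatic carbon would be needed to place other groups against methyl and methoxy. They also leave open how the unsubstituted 1,2,3,4-tetrahydroquinolin-1-yl group compares with morpholin-4-yl on the thiocarbonyl carbon.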